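Changing the thiocarbonyl substituent in the series

The compounds below may be only part of what the source reports. "The series", "measured", "known", "first", "only" and "open" are said of these compounds alone.

For the measured compounds named here, in a functional assay on HCT-116 cells (Homo sapiens) for inhibition, read by CCK-8 assay, with a stated time of 48 h (a higher number here means a weaker inhibitor, a lower number a stronger inhibitor), compound 1 `CCN1CCN(C(=S)SCC(=O)N(Cc2ccc(OC)cc2)c2cc(OC)c(OC)c(OC)c2)CC1` gives 7700 nM, the higher of the two numbers so far, and compound 2 `COc1ccc(CN(C(=O)CSC(=S)N2CCN(C(=O)OC(C)(C)C)CC2)c2cc(OC)c(OC)c(OC)c2)cc1` gives 620 nM. Going by the values given here, the one measured step is a 12-fold lower number from compound 1 to compound 2 (1.09 log units; beyond the scatter), beyond the scatter, with tert-butoxycarbonyl in place of ethyl on an amine nitrogen in a ring.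

Compound 3 `COc1ccc(CN(C(=O)CSC(=S)N2CCc3cc(OC)ccc32)c2cc(OC)c(OC)c(OC)c2)cc1` is still unmeasured. It carries 5-methoxy-2,3-dihydro-1H-indol-1-yl in place of 4-ethylpiperazin-1-yl on a thiocarbonyl carbon. The measured step bears on this change only in part, as the piperazine ring stays in compound 2, whereas here the whole group leaves. Among the compounds with values here, no measured compound carries the incoming group.

Within the data shown here, compound 2, at 620 nM, shows only that a change in this group can lower the number in this assay by a large step. On that single precedent, a lower number of broadly similar size is expected, with wide uncertainty. The expected step is an 8.6-fold lower number from compound 1 to compound 3 (0.93 log units; beyond the scatter). For compound 3 the estimated value is 900 nM, with an expected range from 200 nM to 4000 nM.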

Compound 3, half-maximal inhibitory concentration: 9810 nM
For compound 3 the middle estimate is 11-fold (1.04 log units) below the measured one, and the stated range ends below it.
By their numbers in this assay, from the lowest: compound 2; then compounds 1 and 3 (each within the scatter of the next).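

In this assay, 5-methoxy-2,3-dihydro-1H-indol-1-yl in place of 4-ethylpiperazin-1-yl on the thiocarbonyl carbon gives a 1.3-fold higher number from compound 1 to compound 3 (0.11 log units; within the scatter), so the two compounds stand level even though the entering group has more heavy atoms and adds an aromatic ring. The large step seen with tert-butoxycarbonyl therefore does not extend to every change in this group: among the compounds shown, only compound 2, which keeps the piperazine ring and carries tert-butoxycarbonyl on its nitrogen, lies beyond the scatter from compound 1. No measurement available here explains why these two changes on the same thiocarbonyl carbon part ways.

As far as these compounds go, it remains open whether the lower number of compound 2 depends on tert-butoxycarbonyl itself or would also appear with other piperazine nitrogen substituents, such as acetyl or benzyl. From the compounds shown here alone, for the fused group, the contribution of the methoxy is also open, and the unsubstituted 2,3-dihydro-1H-indol-1-yl group would be needed to address it.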